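Aryl amine exchange on the shared urea core, compound 4

The compounds below may be only part of what the source reports. "The series", "measured", "known", "first", "only" and "open" are said of these compounds alone.

compound 1 `COc1ccc(Br)cc1Nc1cc(NC(=O)Nc2c(Cl)cccc2Cl)ncn1` — 33%
compound 2 `CCc1cccc(Nc2cc(NC(=O)Nc3cc(OC)cc(OC)c3)ncn2)c1` — 36.7%
compound 3 `O=C(Nc1cc(Nc2ccc(F)c(Cl)c2)ncn1)Nc1c(Cl)cccc1Cl` — 47.3%

In a functional assay on NCI-H226 cells (Homo sapiens) for inhibition, read by MTT assay, with a stated time of 48 h, tested at 10 uM (a higher number here means more inhibition at the concentration tested (going by the name of the read-out), a lower number less inhibition), compound 2 gives 36.7%, the second highest of the three numbers. Compound 1 gives 33%, within the scatter of compound 2. Compound 3 gives 47.3%, beyond the scatter and the furthest from compound 2.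

Compound 4 `COc1cc(NC(=O)Nc2cc(Nc3cc(I)ccc3OC)ncn2)cc(OC)c1` has not been measured. It differs from compound 2 in one place: 5-iodo-2-methoxyphenyl in place of 3-ethylphenyl on a nitrogen on an aromatic ring. Among the measured compounds shown here, one measured step concerns the same nitrogen: a number 14.3 percentage points higher from compound 1 to compound 3 (beyond the scatter). There the 5-bromo-2-methoxyphenyl group stood on the lower side of a modest step, and compound 1, which carries it, sits within the scatter of compound 2. For the measured compounds named here, no measured pair joins 3-ethylphenyl to 5-iodo-2-methoxyphenyl directly, and no pair shows iodine against bromine, so the bromo analogue is the only guide. On that basis compound 4 is expected to stay close to compound 2, with a small drop more likely than a rise: a number 4.7 percentage points lower from compound 2 to compound 4 (within the scatter) is expected, a step within the scatter. Compound 4 is estimated at 32%, with a range from 20% to 45%.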

Compound 4, a percentage reported as inhibition, at one concentration (the size of the read-out at that concentration, not a potency): 56.7%
Compound 4: middle estimate off by 24.7 percentage points, on the low side, and the stated range ends below it.
By their numbers in this assay, from the lowest: compounds 1 and 2 (each within the scatter of the next); then compounds 3 and 4 (each within the scatter of the next).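

In this assay, replacing 3-ethylphenyl with 5-iodo-2-methoxyphenyl on a nitrogen on an aromatic ring gives a number 20 percentage points higher from compound 2 to compound 4 (beyond the scatter), so this nitrogen substituent also moves the read-out when the urea carries the partner of compound 2, not only the partner shared by compounds 1 and 3. A 2-methoxyphenyl group carrying a halogen is therefore not tied to the lower side of a step: 5-bromo-2-methoxyphenyl stands there in a number 14.3 percentage points higher from compound 1 to compound 3 (beyond the scatter), whereas 5-iodo-2-methoxyphenyl stands on the higher side on the other urea partner. No available evidence accounts for the rise.

The compounds shown do not separate iodine from bromine, since the two groups sit on different urea partners, nor do they show how much of the step belongs to the methoxy group and how much to the halogen. Also open, going by these compounds, is whether a smaller halogen such as chlorine, or an amine or a carboxylic acid in place of the iodine on the same methoxyphenyl ring, would keep the read-out at the level of compound 4.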